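Alkyl groups on the sulfur: propyl to isopropyl

This account rests on a few compounds, and the source may have more. Where it says the series, first, only, none or still open, it means among the compounds named here.

Compound 2 `CCCSC1=CC(=O)C(C[C@]2(C)[C@@H](C)CC[C@]3(C)C(C)=CCC[C@@H]23)=CC1=O` carries a propyl group on the sulfur. In a functional assay on Fem-X cells (Homo sapiens) for cytotoxicity (a higher number here means a weaker inhibitor, a lower number a stronger inhibitor), compound 2 gives 89500 nM, the highest of the two numbers recorded so far. Its nearest neighbour is compound 1 `CC1=CCC[C@H]2[C@](C)(CC3=CC(=O)C(SC(C)(C)C)=CC3=O)[C@@H](C)CC[C@]12C`, with tert-butyl on the sulfur, which in this assay gives 38000 nM. Among the compounds with values here, the one measured step, a 2.4-fold higher number from compound 1 to compound 2 (0.37 log units; beyond the scatter), is modest and runs toward weaker inhibition as the branched group is replaced by the straight one.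

Compound 3 `CC1=CCC[C@H]2[C@](C)(CC3=CC(=O)C(SC(C)C)=CC3=O)[C@@H](C)CC[C@]12C` is the next member of the series: isopropyl in place of propyl on a sulfur. Isopropyl is branched like tert-butyl yet keeps the count of propyl, so the only step that bears on it is the one from compound 1 to compound 2, and a partial reversal of that modest step is the natural expectation. Compound 3 is therefore expected to sit between its two neighbours, at about 55000 nM, within 25000 nM to 120000 nM, a change of a 1.6-fold lower number from compound 2 to compound 3 (0.21 log units; within the scatter).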

Compound 3, half-maximal inhibitory concentration: 86000 nM
The estimate for compound 3 lay 1.6-fold (0.19 log units) below the measured number; measured number inside the range.
By their numbers in this assay, from the lowest: compound 1; then compounds 3 and 2 (each within the scatter of the next).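

In this assay the change from propyl to isopropyl gives a 1.0-fold lower number from compound 2 to compound 3 (0.02 log units; within the scatter) and so, on this sulfur, branching as such does not separate the two groups. Tert-butyl alone stands apart: removing one of its methyl groups gives a 2.3-fold higher number from compound 1 to compound 3 (0.35 log units; beyond the scatter) and this modest step leaves compound 1 with the lowest number of the three, while compound 2 and compound 3 cannot be ordered. No evidence at hand gives a cause for this difference.

Open, as far as these compounds go, is whether the lower number of compound 1 is particular to tert-butyl or would also appear with another fully substituted group on the sulfur, such as tert-pentyl. Also open, from the compounds shown here alone, is how a longer chain such as hexyl, a phenyl ring or a chain ending in an amine or a carboxylic acid would read here.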